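The compounds below may be only part of what the source reports. "The series", "measured", "known", "first", "only" and "open" are said of these compounds alone.

Among the compounds with values here, the two compounds measured so far share one core. Compound 1, `CC1=CC[C@@H]([C@@](C)(O)CCCC(C)(C)NC=S)CC1`, carries a short sulfur-bearing end group; in a functional assay on UACC-62 cells (Homo sapiens) for cytotoxicity, read by sulforhodamine B assay (on this read-out lower numbers stand for higher toxicity in this test and higher numbers for lower toxicity in this test), compound 1 gives > 100000 nM, which is a limit of the assay and not a number, as the limit of > 100000 nM in this assay, at which 1 of the 2 values shown sits, records. Within the data shown here, compound 2, `CC1=CC[C@@H]([C@@](C)(O)CCCC(C)(C)NC(=S)N/N=C\c2ccc(C)cc2)CC1`, extends that end group with a six-membered aromatic ring of carbon only that bears a methyl group; in this assay compound 2 gives 52300 nM. Among the measured compounds shown here, compound 2 thus holds the only actual number among the values measured here. Compound 3, `CC1=CC[C@@H]([C@@](C)(O)CCCC(C)(C)NC(=S)N/N=C\c2ccc(O)cc2)CC1`, differs from compound 2 in one place: hydroxy in place of methyl on an aromatic carbon. For the measured compounds named here, no measured pair shows this change, so its effect is not known from these data. Compared with compound 2 only a modest step is expected, most likely within the usual scatter or a little toward lower toxicity, so the step expected is a 1.2-fold higher number from compound 2 to compound 3 (0.09 log units; within the scatter). Compound 3 is therefore estimated at 65000 nM, with a range from 25000 nM to 160000 nM.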

Compound 3, concentration lethal to 50% of the cells: 55600 nM
Compound 3: middle estimate off by 1.2-fold (0.07 log units), on the high side; measured number inside the range.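

In this assay, putting hydroxy in place of methyl on the aromatic ring gives a 1.1-fold higher number from compound 2 to compound 3 (0.03 log units; within the scatter), so the two compounds cannot be told apart on this read-out. Within the data shown here, this is the first comparison here between two actual numbers, and it shows that at this position, para to a large group, a group with one hydrogen-bond donor and one hydrogen-bond acceptor reads the same as a group with neither. The data shown offer no explanation for why these two groups read alike.

Methyl and hydroxy are only two samples of what this position could hold, so an amine, a carboxylic acid or a chlorine atom on the same aromatic carbon might still separate clearly from them. As far as these compounds go, whether a longer chain there, such as propyl or butyl, would give a number well away from that of compound 3 also remains open.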